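The source may hold more compounds than are shown below. What is called first, only, known or untested is meant among the compounds shown, and "the series" means these compounds.

Measured compounds:
compound 1 `COc1cccc(-c2nc3cccc(-c4cc(OC)c(OC)c(OC)c4)c3o2)c1`: > 25000 nM
compound 2 `COc1cc(-c2cccc3nc(-c4ccc(Br)cc4)oc23)cc(OC)c1OC`: > 25000 nM

In a functional assay on NCI-H460 cells (Homo sapiens) for antiproliferative activity, read by MTT assay, with a stated time of 48 h (on this read-out lower numbers stand for stronger inhibition and higher numbers for weaker inhibition), compound 1 gives only a limit, > 25000 nM. Compound 2 likewise gives only a limit, > 25000 nM. Among the compounds with values here, the single measured step, a step that the two limits leave unreadable from compound 1 to compound 2, is therefore of unreadable size. Compound 3 `COc1cc(-c2cccc3nc(-c4cccc(N)c4)oc23)cc(OC)c1OC` differs from compound 2 in one place: 3-aminophenyl in place of 4-bromophenyl on an aromatic carbon. Within the data shown here, no measured step bears on an aminophenyl change; the only evidence is the limit of > 25000 nM in this assay, at which 2 of the 2 values shown sit. Compound 3 is expected to remain near that limit, the step of a number no higher from compound 2 to compound 3 (the limit leaves the size open) being expected to stay unresolved. The estimate for compound 3 in this assay is 25000 nM, range 8000 nM to 60000 nM.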

Compound 3, half-maximal inhibitory concentration: 2600 nM
The estimate for compound 3 lay 9.6-fold (0.98 log units) above the measured number, outside the stated range (below it).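

In this assay, 3-aminophenyl on this aromatic carbon gives a readable number, with an at least 9.6-fold lower number from compound 2 to compound 3 (0.98 log units; beyond the scatter) and, for amino in place of methoxy, an at least 9.6-fold lower number from compound 1 to compound 3 (0.98 log units; beyond the scatter). The step between compound 1 and compound 2 cannot be read, both values being limits. Of the three aryl groups shown at this place, only 3-aminophenyl brings the value off the limit: the limit of > 25000 nM in this assay, at which 2 of the 3 values shown sit.

Going by these compounds, whether the amino group must sit where it does in compound 3 stays open; 4-aminophenyl would bear on that. On these data alone, whether a free amine is required also stays open, and 3-hydroxyphenyl or 3-acetamidophenyl would bear on that.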